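The compounds below may be only part of what the source reports. "The series", "measured", "known", "first", "only" and "open" are said of these compounds alone.

Working notes on a series built on one shared core. Compound 1 `CCOC(=O)c1sc(-c2cccc(NC(=O)c3ccccc3F)c2)nc1Nc1ccc(N2CCN(C)CC2)cc1` gives 2000 nM in a functional assay on Ramos cells (Homo sapiens) for antiproliferative activity, read by CCK-8 assay, with a stated time of 72 h; a higher number here means a weaker inhibitor, a lower number a stronger inhibitor. Compound 2 `CCOC(=O)c1sc(-c2cccc(NC(=O)c3ccc(Cl)cc3)c2)nc1Nc1ccc(N2CCN(C)CC2)cc1` has only "not determined" (no result reported) in this assay, and compound 3 `CCOC(=O)c1sc(-c2cccc(NC(=O)c3ccc(C(F)(F)F)cn3)c2)nc1Nc1ccc(N2CCN(C)CC2)cc1` likewise has only "not determined" (no result reported) there, so compound 2 stands without a measured reference of its own and without a measured neighbour; only compound 1 anchors the series. The change from compound 2 to compound 4 `CN1CCN(c2ccc(Nc3nc(-c4cccc(NC(=O)c5ccc(Cl)cc5)c4)sc3C(=O)O)cc2)CC1` is hydrogen in place of ethyl on an oxygen next to a carbonyl group, ethoxycarbonyl to carboxy. Among the measured compounds shown here, no measured pair spans this change, so its size rests on expectation alone: a weakening beyond the scatter is expected, with wide uncertainty and a real chance of no number at all. Compound 4 is expected in this assay to give 6000 nM, with a range from 1200 nM to 30000 nM.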

Compound 4, half-maximal inhibitory concentration: 23300 nM
For compound 4 the middle estimate is 3.9-fold (0.59 log units) below the measured one; low and high end bracket the measured number.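

Among the compounds shown here, compound 2 has no single number in this assay, so no step to compound 4 can be read. The compounds shown leave open the size of the ethoxycarbonyl to carboxy change. No evidence bears on this result.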